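The compounds below may be only part of what the source reports. "The series", "measured", "known", "first", "only" and "open" are said of these compounds alone.

The account starts from compound 1, `CC1=CC[C@H](C(C)(C)N=C=S)CC1`, and three compounds sharing its core: compound 2, `CC1=CC[C@H](C(C)(C)NC(=S)N/N=C/c2ccc(N(C)C)cc2)CC1`, compound 3, `CC1=CC[C@H](C(C)(C)NC(=S)N/N=C/c2ccc(F)cc2)CC1`, and the still unmeasured compound 4, `CC1=CC[C@H](C(C)(C)NC(=S)N/N=C/c2cccs2)CC1`. In a functional assay on NCI-H460 cells (Homo sapiens) for inhibition, read by sulforhodamine B assay, with a stated time of 48 h (a higher number here means a weaker inhibitor of growth, a lower number a stronger inhibitor of growth), compound 1 gives only a limit, > 100000 nM. Compound 2 gives 53400 nM. Compound 3 likewise stands at a limit, > 100000 nM. Its position is thus fixed only by the limit of > 100000 nM in this assay, at which 2 of the 3 values shown sit. Going by the values given here, the single measured step, an at least 1.8-fold higher number from compound 2 to compound 3 (0.27 log units; that floor lies within the scatter), exchanges a group on an aromatic carbon, not the ring itself. Compound 4 differs by thiophen-2-yl in place of 4-fluorophenyl on a carbon with a double bond to nitrogen. Among the compounds with values here, no measured step covers such a ring exchange, so the expected step of a number no higher from compound 3 to compound 4 (the limit leaves the size open) is none beyond the scatter. Compound 4 is therefore estimated at 100000 nM, between 35000 nM and 300000 nM, with a good chance of another limit.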

Compound 4, concentration for 50% growth inhibition: 10800 nM
Estimate against measurement, compound 4: 9.3-fold (0.97 log units) above; the whole stated range lies above it.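

In this assay, exchanging the aromatic ring itself on the carbon with a double bond to nitrogen moves the read-out, which no change shown before had done beyond the scatter: thiophen-2-yl in place of 4-fluorophenyl gives an at least 9.2-fold lower number from compound 3 to compound 4 (0.96 log units; beyond the scatter). Compound 2 stands at 53400 nM, a higher number than compound 4 at 10800 nM. The size of the step remains a floor, because compound 3 sits at a limit: the limit of > 100000 nM in this assay, at which 2 of the 4 values shown sit.

The compounds shown leave open whether a furan-2-yl or pyridin-2-yl ring would act like thiophen-2-yl. They also leave open what a methyl group on the thiophene ring would do.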